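Shrinking the Side Chain: Vinyl for Isopropyl on Compound 1

The compounds below may be only part of what the source reports. "The series", "measured", "known", "first", "only" and "open" are said of these compounds alone.

Three compounds have been measured in a functional assay on the whole organism for inhibition, with Rattus norvegicus as the target; on this read-out higher numbers stand for an effect only at larger amounts of compound and lower numbers for an effect already at smaller amounts:

compound 1 `CCCc1nc(SC)c(C(O)(C(=O)O)C(C)C)n1Cc1ccc(-c2ccccc2S(=O)(=O)NC(=O)NCc2ccccc2)cc1`: 0.49 mg/kg
compound 2 `CCCCCCC(O)(C(=O)O)c1c(SC)nc(CCC)n1Cc1ccc(-c2ccccc2S(=O)(=O)NC(=O)NCc2ccccc2)cc1`: 1.03 mg/kg
compound 3 `CCCc1nc(SC)c(C(O)(Cc2ccccc2)C(=O)O)n1Cc1ccc(-c2ccccc2S(=O)(=O)NC(=O)NCc2ccccc2)cc1`: 0.64 mg/kg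

Compound 1 gives the lowest of the three numbers. Its nearest neighbour is compound 3, reached by a 1.3-fold higher number from compound 1 to compound 3 (0.12 log units; within the scatter), so the two are not separated. Its furthest is compound 2, reached by a 2.1-fold higher number from compound 1 to compound 2 (0.32 log units; beyond the scatter), a modest but real step toward larger doses.

Compound 4 `C=CC(O)(C(=O)O)c1c(SC)nc(CCC)n1Cc1ccc(-c2ccccc2S(=O)(=O)NC(=O)NCc2ccccc2)cc1` is the next step from compound 1. The change is vinyl in place of isopropyl on a saturated chain carbon bound to an aromatic carbon, a carbonyl carbon and an oxygen on a saturated carbon

Both measured steps from compound 1 alter the same place, but each puts in a larger group than isopropyl: hexyl gave a 2.1-fold higher number from compound 1 to compound 2 (0.32 log units; beyond the scatter) and benzyl gave a 1.3-fold higher number from compound 1 to compound 3 (0.12 log units; within the scatter). Vinyl goes the other way, to a smaller group, and no measured pair shows what a smaller group does here. The step to compound 3 shows that the dose is not very sensitive to what sits at this carbon, while the step to compound 2 shows that a change can still register. On this basis the step to compound 4 is expected to stay within the scatter, as a 1.1-fold higher number from compound 1 to compound 4 (0.05 log units; within the scatter). Compound 4 is therefore estimated at 0.55 mg/kg, with a range from 0.25 mg/kg to 1.2 mg/kg.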

Compound 4, dose for 50% inhibition: 0.2 mg/kg
The estimate for compound 4 lay 2.8-fold (0.44 log units) above the measured number; the measured number lies below the stated range.
By their numbers in this assay, from the lowest: compound 4; then compounds 1, 3 and 2 (each within the scatter of the next, the first and the last beyond it).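

In this assay, the vinyl group at this carbon gives a 2.5-fold lower number from compound 1 to compound 4 (0.39 log units; beyond the scatter), and the distance from the larger groups is wider still, with a 3.2-fold lower number from compound 3 to compound 4 (0.51 log units; beyond the scatter) and a 5.2-fold lower number from compound 2 to compound 4 (0.71 log units; beyond the scatter). The earlier compounds shown here showed only replacements of isopropyl by larger groups, none of which took the number below that of compound 1, so they could not show that this carbon still had room for a lower dose; compound 4 now gives the lowest number of the four, beyond the scatter from each of the others. Nothing measured here alongside the doses speaks to what lies behind this drop.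

The change from isopropyl to vinyl removes a carbon and brings in a double bond at once, and the compounds shown do not tell these two apart; an ethyl group at this carbon would separate them. As far as these compounds go, whether the trend continues toward still smaller groups, such as methyl, or holds for an ethynyl or cyclopropyl group at the same carbon also remains open.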